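Thiophen-2-yl in place of 4-nitrophenyl: from compound 1 to compound 4

The source may report more compounds than this note shows. Statements on the series, on what has been measured and on what is new or still open speak of the compounds shown alone.

Measured compounds:
compound 1, `COc1ccc(S(=O)(=O)N2CCc3cccc(-c4ccc([N+](=O)[O-])cc4)c32)cc1`, 51.3 nM
compound 2, `COc1ccc(S(=O)(=O)N2CCc3cccc(-c4cccc(F)c4)c32)cc1`, 92.4 nM
compound 3, `COc1ccc(S(=O)(=O)N2CCc3cccc(-c4ccc(O)cc4)c32)cc1`, 123 nM

Three compounds sharing one core were tested in a functional assay on KB-VIN10 cells (Homo sapiens) for inhibition, with a stated time of 72 h; on this read-out higher numbers stand for weaker inhibition and lower numbers for stronger inhibition. Compound 1 gives the lowest number of the three. Compound 2 lies nearest to it, a 1.8-fold higher number from compound 1 to compound 2 (0.26 log units; within the scatter), and compound 3 lies furthest, a 2.4-fold higher number from compound 1 to compound 3 (0.38 log units; beyond the scatter). Between compound 2 and compound 3 the step is a 1.3-fold higher number from compound 2 to compound 3 (0.12 log units; within the scatter).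

Compound 4, `COc1ccc(S(=O)(=O)N2CCc3cccc(-c4cccs4)c32)cc1`, is not yet measured. It differs from compound 1 in one place: thiophen-2-yl in place of 4-nitrophenyl on an aromatic carbon.

Among the compounds with values here, two measured steps bear on this change, since both start from compound 1 and both remove the 4-nitrophenyl group or its nitro: the step to compound 2, a 1.8-fold higher number from compound 1 to compound 2 (0.26 log units; within the scatter), and the step to compound 3, a 2.4-fold higher number from compound 1 to compound 3 (0.38 log units; beyond the scatter). Each of them gave a higher number, one within the scatter and one modestly beyond it. Compound 4 is therefore expected to follow the same direction, with a step of a 2.1-fold higher number from compound 1 to compound 4 (0.33 log units; beyond the scatter) in this assay. The value of compound 4 is estimated at 110 nM, with a range from 50 nM to 250 nM.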

Compound 4, half-maximal inhibitory concentration: 251 nM
Beside the measured number, compound 4's estimate is 2.3-fold (0.36 log units) below it; measured number outside the range, above it.
By their numbers in this assay, from the lowest: compounds 1, 2 and 3 (each within the scatter of the next, the first and the last beyond it); then compound 4.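

In this assay the result suggests that this aromatic carbon responds to the ring itself and not only to what the ring carries: the 4-nitrophenyl, 3-fluorophenyl and 4-hydroxyphenyl groups all keep a six-membered aromatic ring of carbon only, whereas thiophen-2-yl, a five-membered aromatic ring with 1 hetero atom, gives the largest step of the set (a 4.9-fold higher number from compound 1 to compound 4 (0.69 log units; beyond the scatter)). The rise is not confined to the comparison with the nitro compound, as the number also goes up against the fluoro compound (a 2.7-fold higher number from compound 2 to compound 4 (0.43 log units; beyond the scatter)) and against the hydroxy compound (a 2.0-fold higher number from compound 3 to compound 4 (0.31 log units; beyond the scatter)). Each of these steps lies beyond the scatter, which makes compound 4 the weakest of the four in this assay.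

Compound 4 alone carries a five-membered ring, so these compounds cannot separate the ring size from the sulfur or from the absence of a substituent, a question that a furan-2-yl, thiophen-3-yl or unsubstituted phenyl group at this carbon would bear on. No measurement at hand gives a reason for the step.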